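The compounds below may be only part of what the source reports. "The series", "measured", "known", "first", "only" and "open" are said of these compounds alone.

Two measured compounds share the core of compound 1 `NNC(=O)CCc1ccncc1-c1ccc2ccccc2c1`. In an assay on a protein complex for inhibition of CDK8/Cyclin C (Homo sapiens), with a stated time of 1 h (a higher number here means a weaker inhibitor, a lower number a stronger inhibitor), compound 1 gives 7.7 nM. Compound 2 `O=C(/C=C/c1ccncc1-c1ccc2[nH]ccc2c1)N1CCOCC1` gives in this assay 190 nM, the higher of the two numbers, so compound 1 stands at the lower end of what has been measured, with compound 2 beyond the scatter above it.

Compound 3 `CNC(=O)CCc1ccncc1-c1ccc2ccccc2c1` has not yet been measured in this assay. It differs from compound 1 in a single place: methyl in place of amino on an amide-type nitrogen. Going by the values given here, no pair of measured compounds differs by exactly this change, so no measured step shows how large its effect is, and the expectation rests on compound 1 alone, which gives 7.7 nM in this assay. The step from compound 1 to compound 3 is expected to be a moderate rise in the number, somewhat beyond the scatter, a 3.2-fold higher number from compound 1 to compound 3 (0.51 log units; beyond the scatter). For compound 3 the half-maximal inhibitory concentration in this assay is therefore estimated at 25 nM, with a likely range from 6 nM to 100 nM.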

Compound 3, half-maximal inhibitory concentration: 21.1 nM
Estimate against measurement, compound 3: 1.2-fold (0.07 log units) above; the measured number falls inside the stated range.
By their numbers in this assay, from the lowest: compound 1; then compound 3; then compound 2.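

Methyl in place of amino on an amide-type nitrogen gives a 2.7-fold higher number from compound 1 to compound 3 (0.44 log units; beyond the scatter), a modest step but the first measured change at this position. It shows that the amino group, which counts one hydrogen-bond donor and one hydrogen-bond acceptor, is not essential for strong inhibition here: in this assay compound 3, whose methyl counts neither, still gives 21.1 nM, although the change does cost some potency relative to compound 1. No measurement shown explains the size of this step.

This single step cannot separate what is lost with the amino group from what is gained with the methyl, and an unsubstituted amide, a hydroxyl group or a longer chain such as ethyl on the same nitrogen would be needed to tell these apart. It also remains open whether the same replacement would have a step of similar size on another core, as the one pair shown rests entirely on the core of compound 1.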